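Swapping Bromo for Nitro on a Shared Core

This account rests on a few compounds, and the source may have more. Where it says the series, first, only, none or still open, it means among the compounds named here.

Of the compounds shown here, three built on closely related cores have been tested in a functional assay on PC-3 cells (Homo sapiens) for inhibition, read by MTT assay, with a stated time of 72 h; on this read-out lower numbers stand for stronger inhibition and higher numbers for weaker inhibition. Compound 1 `O=C(CSc1nc(Nc2ccccc2)c2ccccc2n1)Nc1ccc(Br)cc1` gives 8450 nM. Compound 2 `O=C(CSc1nc(Nc2ccccc2)c2ccccc2n1)Nc1ccc([N+](=O)[O-])cc1` differs from it by nitro in place of bromo on an aromatic carbon, and in this assay compound 2 gives 25000 nM; the step is a 3.0-fold higher number from compound 1 to compound 2 (0.47 log units; beyond the scatter). Compound 3 `C=CC(=O)Nc1cccc(NC(=O)CSc2nc(Nc3cccc(Br)c3)c3ccccc3n2)c1` rests on a different core, and the difference between the cores of compound 1 and compound 3 is not broken down here. In this assay compound 3 gives 15000 nM, a number that sits within the scatter of both compound 2 and compound 1, so no order among the three can be read from it.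

Compound 4 `C=CC(=O)Nc1cccc(NC(=O)CSc2nc(Nc3cccc([N+](=O)[O-])c3)c3ccccc3n2)c1` has not yet been measured. It differs from compound 3 by nitro in place of bromo on an aromatic carbon. Within the data shown here, this is the same kind of change as the one separating compound 1 from compound 2, not the same change: in compound 1 the bromo sits para to a large group, while in compound 3 it sits meta to a large group. Among the measured compounds shown here, only one earlier step of this kind is known, made on a different core and at a different place, so the expectation is loose and leans on the step of a 3.0-fold higher number from compound 1 to compound 2 (0.47 log units; beyond the scatter). For compound 4 the step expected is a 2.3-fold higher number from compound 3 to compound 4 (0.37 log units; beyond the scatter). Compound 4 is therefore estimated at 35000 nM, with a likely range from 12000 nM to 100000 nM.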

Compound 4, half-maximal inhibitory concentration: 46300 nM
Beside the measured number, compound 4's estimate is 1.3-fold (0.12 log units) below it, within the range that was stated.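

In this assay, nitro in place of bromo on an aromatic carbon again moves the number upward, and the new step is a 3.1-fold higher number from compound 3 to compound 4 (0.49 log units; beyond the scatter). Set beside the earlier step, the change carries over from one core to the other with no visible difference in size: the same change on two cores in this assay, a 3.0-fold higher number (0.47 log units; beyond the scatter) from compound 1 to compound 2 and a 3.1-fold higher number (0.49 log units; beyond the scatter) from compound 3 to compound 4, 1.0-fold (0.02 log units) apart, within the scatter of two such steps. Among these compounds, this agreement rests on only two pairs in a single cell assay, and those pairs differ both in their core and in where the exchanged group sits, so it neither shows why the number moves nor establishes that a step of this size would appear on any other core.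

The compounds shown leave open whether this agreement extends beyond the exchange of bromo for nitro, since no pair here tells how an amine, a methoxy group or a nitrile on the same aromatic carbon would compare with either group on these two cores. They also leave open whether core and place each influence the step on their own, as the two pairs vary both at once and cannot separate them.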